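The source may report more compounds than this note shows. Statements on the series, on what has been measured and on what is new or still open speak of the compounds shown alone.

Measured so far in an ADME assay on the whole organism (Rattus norvegicus, strain Sprague-Dawley) for pharmacokinetics, with a stated time of 6 h, at a dose of 10 mg/kg by the oral route; a higher number here means more compound in the circulation at the dose given, a lower number less compound in the circulation:

- compound 1 `Cc1cn2cc(-c3cc4ccc(N5CCN(C)CC5)cc4c(=O)o3)nc2c(C)n1`: 790 ng.h/mL
- compound 2 `Cc1cn2nc(-c3cc(=O)n4cc(N5CCN(C)CC5)ccc4n3)cc2c(C)n1`: 2100 ng.h/mL
- compound 3 `Cc1cn2cc(-c3cc4ccc(N5CCNCC5)cc4c(=O)o3)nc2c(C)n1`: 280 ng.h/mL

Compound 2 stands highest of the three numbers in this assay; its steps to compound 1 and to compound 3 are both beyond the scatter. Compound 1 and compound 2 carry different cores; the difference between the two cores is not broken down here. Within the core of compound 1, the change hydrogen in place of methyl on an amine nitrogen in a ring gives the step of a 2.8-fold lower number from compound 1 to compound 3 (0.45 log units; beyond the scatter), a modest drop that lies beyond the scatter.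

Compound 4 `Cc1cn2nc(-c3cc(=O)n4cc(N5CCNCC5)ccc4n3)cc2c(C)n1` is not yet measured. It differs from compound 2 by hydrogen in place of methyl on an amine nitrogen in a ring, which is the same change that carries compound 1 to compound 3, at the same place on the same ring. Going by the values given here, on the one measured example of this change, compound 4 is expected to sit below compound 2 by a step of about a 2.8-fold lower number from compound 2 to compound 4 (0.45 log units; beyond the scatter), because compound 3 fell against compound 1 by a 2.8-fold lower number from compound 1 to compound 3 (0.45 log units; beyond the scatter). Only one prior occurrence of the change is in hand, and it sits on a different core, so the step for compound 4 is an estimate with wide bounds. Compound 4 is expected to give about 750 ng.h/mL in this assay, most likely between 350 ng.h/mL and 1600 ng.h/mL.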

Compound 4, area under the concentration-time curve: 380 ng.h/mL
For compound 4 the middle estimate is 2.0-fold (0.30 log units) above the measured one, and the stated range covers the measured number.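

In this assay, going from 4-methylpiperazin-1-yl to piperazin-1-yl on the second core gives a 5.5-fold lower number from compound 2 to compound 4 (0.74 log units; beyond the scatter), so the fall seen on the first core recurs here. Set side by side, the two steps run the same way and the gap between them does not exceed what repeated measurement would give: the same change on two cores in this assay, a 2.8-fold lower number (0.45 log units; beyond the scatter) from compound 1 to compound 3 and a 5.5-fold lower number (0.74 log units; beyond the scatter) from compound 2 to compound 4, 2.0-fold (0.29 log units) apart, within the scatter of two such steps. On these two cores the change therefore carries over in direction and, within the scatter, in size; two pairs do not establish a fixed step for the series, do not explain why the number falls, and say nothing about any third core.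

Still open, from the compounds shown here alone, is where other groups on the ring nitrogen, such as ethyl, 2-hydroxyethyl or acetyl, would stand relative to methyl and hydrogen in this assay. Also open, going by these compounds, is whether the same change would give a similar step at another dose or by another route.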